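Dropping a Cyano Group: From Compound 1 to Compound 3

The source may hold more compounds than are shown below. What is called first, only, known or untested is meant among the compounds shown, and "the series" means these compounds.

Going by the values given here, compound 1 `N#Cc1ccc(NC(=S)N/N=C/c2ccc3ccccc3n2)cc1` gives the highest of the two numbers measured so far in a functional assay on SGC-7901 cells (Homo sapiens) for antiproliferative activity, read by sulforhodamine B assay, with a stated time of 72 h (on this read-out higher numbers stand for weaker inhibition and lower numbers for stronger inhibition), where compound 1 gives 23700 nM. Compound 2 `CN(C)C(=S)N/N=C/c1cnc2ccccc2n1`, built on a different core, gives 170 nM in this assay, a gap well beyond the scatter. Compound 3 `S=C(N/N=C/c1ccc2ccccc2n1)Nc1ccccc1` differs from compound 1 by hydrogen in place of cyano on an aromatic carbon. Among the compounds with values here, no pair of measured compounds shows this same change, so its effect is unknown. A step of roughly the size of the scatter, possibly toward a lower number, is expected a 1.6-fold lower number from compound 1 to compound 3 (0.20 log units; within the scatter). Compound 3 is therefore estimated at 15000 nM, within a range from 4000 nM to 60000 nM.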

Compound 3, half-maximal inhibitory concentration: 26500 nM
Estimate against measurement, compound 3: 1.8-fold (0.25 log units) below, and the stated range covers the measured number.
By their numbers in this assay, from the lowest: compound 2; then compounds 1 and 3 (each within the scatter of the next).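

Replacing the nitrile of the 4-cyanophenyl group with hydrogen, which leaves a plain phenyl, gives a 1.1-fold higher number from compound 1 to compound 3 (0.05 log units; within the scatter) in this assay and so produces no change that can be told from ordinary repeat variation. At this position, then, the nitrile is not needed to keep the activity seen with compound 1. No further data bear on why this swap leaves the number in place. Going by these compounds, whether an amine, a carboxylic acid or a methoxy group on this aromatic carbon would shift the number remains open. So does whether hydrogen in place of nitrile would behave the same way on a different core.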